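This account rests on a few compounds, and the source may have more. Where it says the series, first, only, none or still open, it means among the compounds named here.

In a physicochemical assay for lipophilicity (on this read-out higher numbers stand for higher lipophilicity and lower numbers for lower lipophilicity), compound 1 (`CCCCS(=O)(=O)c1ccc(O)c(C(=O)Nc2ccc(C(F)(F)F)cc2)c1`) gives 4.14 and compound 2 (`CCCCCCCCS(=O)(=O)c1ccc(O)c(C(=O)Nc2ccc(C(F)(F)F)cc2)c1`) gives 6.3, while compound 3 (`CCCCCCCCCCCCS(=O)(=O)c1ccc(O)c(C(=O)Nc2ccc(C(F)(F)F)cc2)c1`) gives 8.46 as the highest of the three. Compound 4 (`CS(=O)(=O)c1ccc(O)c(C(=O)Nc2ccc(C(F)(F)F)cc2)c1`) carries hydrogen in place of undecyl on a saturated chain carbon bound to a sulfonyl sulfur. The three chain steps bear on this: a number 2.16 log units higher from compound 1 to compound 2 (beyond the scatter) and a number 2.16 log units higher from compound 2 to compound 3 (beyond the scatter) with butyl added, and a number 4.32 log units higher from compound 1 to compound 3 (beyond the scatter) with octyl added. All three are large, and they grow in step with chain length. No measured chain is shorter than butyl, so the extrapolation carries extra uncertainty. A large drop is expected in this assay for this removal, beyond any measured step. The expected change is a number 5.94 log units lower from compound 3 to compound 4 (beyond the scatter) on this reading. Compound 4 is estimated at 2.52 with an expected range of 2.1 to 3 in this read-out.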

Compound 4, partition coefficient: 2.52
For compound 4 middle estimate and measured number coincide at the digits printed, and the stated range covers the measured number.
By their numbers in this assay, from the lowest: compound 4; then compound 1; then compound 2; then compound 3.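

In this assay hydrogen in place of propyl gives a number 1.62 log units lower from compound 1 to compound 4 (beyond the scatter) and hydrogen in place of heptyl gives a number 3.78 log units lower from compound 2 to compound 4 (beyond the scatter) while hydrogen in place of undecyl gives a number 5.94 log units lower from compound 3 to compound 4 (beyond the scatter) on the saturated chain carbon bound to a sulfonyl sulfur. The steps grow with the chain that leaves, so the trend now reaches below butyl, and none of the four compounds goes against it. No supporting evidence explains this result. Still open, as far as these compounds go, is whether a branched chain, a chain ending in an amine or a carboxylic acid, or a longer chain would follow the same trend.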